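This account rests on a few compounds, and the source may have more. Where it says the series, first, only, none or still open, it means among the compounds named here.

Measured so far in a functional assay on K562 cells (Homo sapiens) for antiproliferative activity, read by MTT assay, with a stated time of 48 h; on this read-out higher numbers stand for weaker inhibition and lower numbers for stronger inhibition:
- compound 1 `CCn1c(N)c(-c2nc3ccccc3[nH]2)c2nc(C#N)c(C#N)nc21`: > 50000 nM
- compound 2 `N#Cc1nc2c(-c3nc4ccccc4[nH]3)c(N)n(CCO)c2nc1C#N`: > 50000 nM
- compound 3 `CN1CCN(CCCn2c(N)c(-c3nc4ccccc4[nH]3)c3nc(C#N)c(C#N)nc32)CC1`: 1260 nM

In this assay compound 1 gives only a limit of the assay, > 50000 nM, not a number. Compound 2 likewise gives only a limit, > 50000 nM. Compound 3 gives 1260 nM. Compound 1 thus stands at the limit of > 50000 nM in this assay, at which 2 of the 3 values shown sit, with no number of its own.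

Compound 4 `N#Cc1nc2c(-c3nc4ccccc4[nH]3)c(N)n(CCCN3CCCCC3)c2nc1C#N` has not yet been measured. It differs from compound 1 by (piperidin-1-yl)methyl in place of hydrogen on a saturated chain carbon, two bonds along the chain from an aromatic nitrogen. The closest measured step is the one where a (4-methylpiperazin-1-yl)methyl enters at the same place, and that step is an at least 39-fold lower number from compound 1 to compound 3 (1.59 log units; beyond the scatter). The step of an at least 39-fold lower number from compound 2 to compound 3 (1.59 log units; beyond the scatter) points the same way. Both are known only as bounds, as compound 1 gives only a limit, > 50000 nM.

A change of like kind at the same place is expected to lower the number strongly as well, so the expected step is an at least 33-fold lower number from compound 1 to compound 4 (1.52 log units; beyond the scatter). Compound 4 is therefore estimated at 1500 nM, with a range from 400 nM to 6000 nM.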

Compound 4, half-maximal inhibitory concentration: 3460 nM
Compound 4: the middle estimate sits 2.3-fold (0.36 log units) below what was measured; measured number inside the range.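

In this assay, the drop seen with compound 3 does not depend on the 4-methylpiperazin-1-yl group, since a 3-(piperidin-1-yl)propyl chain on the same core also gives an at least 14-fold lower number from compound 1 to compound 4 (1.15 log units; beyond the scatter), and likewise an at least 14-fold lower number from compound 2 to compound 4 (1.15 log units; beyond the scatter). Both steps are only bounds, because compound 1 and compound 2 each sit at a limit of the assay, not at a number: the limit of > 50000 nM in this assay, at which 2 of the 4 values shown sit. The choice of ring at the chain end still counts for something, with a 2.7-fold higher number from compound 3 to compound 4 (0.44 log units; beyond the scatter).

Open still is whether a ring is needed at all, which a plain dimethylamino group at the end of the propyl chain could show, and whether a morpholine ring behaves like these two. On these data alone, the effect of a longer chain carrying the same piperidin-1-yl group also remains unknown.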